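The source may report more compounds than this note shows. Statements on the series, on what has been measured and on what is new or still open speak of the compounds shown alone.

Compound 1 `C=CCNC(=O)n1c(-c2ccc(OC)cc2)cc(=O)c2c(OC)cc(OC)cc21` is the reference point of this comparison. In a functional assay on KOPN-8 cells (Homo sapiens) for antiproliferative activity, with a stated time of 72 h (a higher number here means that more compound is needed for the effect, a lower number that less compound is needed), compound 1 gives 12000 nM, the highest of the two numbers on record, with compound 3 standing closest to it. Compound 3 `COC(=O)c1cc(=O)c2c(OC)cc(OC)cc2n1S(=O)(=O)c1ccc(C)cc1` gives 6000 nM in this assay, a number within the scatter of that of compound 1, so no order between the two can be claimed. Compound 2 `COC(=O)c1cc(=O)c2c(OC)cc(OC)cc2[nH]1` gives only a limit of this assay, > 34400 nM; this is the limit of > 34400 nM in this assay, at which 1 of the 3 values shown sits. Compound 4 `COc1ccc(-c2cc(=O)c3c(OC)cc(OC)cc3n2S(=O)(=O)c2ccc(C#N)cc2)cc1` has not yet been measured. It differs from compound 1 by (4-cyanophenyl)sulfonyl in place of allylcarbamoyl on an aromatic nitrogen. Among the measured compounds shown here, no step between measured compounds that differ in one place is available, so the measured values can only be set beside one another, and compound 1 and compound 3 show numbers within the scatter of each other. The expected step is a 2.0-fold lower number from compound 1 to compound 4 (0.30 log units; within the scatter), downward and of about the size of the usual scatter. For compound 4 the estimate in this assay is 6000 nM, with a range from 1500 nM to 25000 nM.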

Compound 4, half-maximal effective concentration: > 17200 nM
Compound 4 ended at the assay's limit (the forecaster's own chance of this, stated with the estimate: 10%); middle value at least 2.8-fold (0.45 log units) from the limit.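

Compound 4 gives only a limit in this assay, not a number: the limit of > 17200 nM in this assay, at which 1 of the 4 values shown sits. Putting (4-cyanophenyl)sulfonyl in place of allylcarbamoyl on the aromatic nitrogen gives an at least 1.4-fold higher number from compound 1 to compound 4 (0.15 log units; that floor lies within the scatter). Among the compounds shown here, this is the first reading of a change in one place at this position, ortho to the 4-methoxyphenyl group, and it shows that this sulfonyl group brings no lower number than the allylcarbamoyl group, although only the floor of the step is known and its full size is not.

The compounds shown leave open how far the number rises with this change and whether the nitrile on the aromatic ring plays any part in it. They also leave open what a free amine or a longer alkyl chain on this nitrogen would do.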